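The compounds below may be only part of what the source reports. "The series", "measured", "known", "first", "only" and "open" are said of these compounds alone.

Of the compounds shown here, two of a shared core have been measured in a functional assay on the whole organism (strain Wistar) for inhibition, with Rattus norvegicus as the target, with a stated time of 5 days, at a dose of 50 mg/kg by the oral route; on this read-out lower numbers stand for less inhibition and higher numbers for more inhibition at the one dose given (going by the name of the read-out). Compound 1, `CCOc1ccc2cc(CCC(C)=O)ccc2c1`, gives 12%. Compound 2, `CC(=O)/C=C/c1ccc2cc(C)ccc2c1`, gives 29%, the higher of the two numbers, and its gap to compound 1 lies beyond the usual scatter. Compound 3, `CC(=O)CCc1ccc2cc(C)ccc2c1`, has not been measured; it differs from compound 2 in one place: 2-acetylethyl in place of 2-acetylethenyl on an aromatic carbon. With this change compound 3 comes to carry the same 2-acetylethyl chain that compound 1 carries, and compound 1 sits at the low end of the two numbers with 12%. The step of a number 14 percentage points lower from compound 2 to compound 3 (beyond the scatter) is therefore expected to be downward and of a size beyond the scatter. Compound 3 is estimated to give about 15% in this assay, with a likely range from 3% to 30%.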

Compound 3, a percentage reported as inhibition, in the whole organism at one dose (the size of the read-out at that dose, not a potency): 34%
Beside the measured number, compound 3's estimate is 19 percentage points below it, outside the stated range (above it).
By their numbers in this assay, from the lowest: compound 1; then compounds 2 and 3 (each within the scatter of the next).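

In this assay, 2-acetylethyl in place of 2-acetylethenyl on an aromatic carbon gives a number 5 percentage points higher from compound 2 to compound 3 (within the scatter), so at this position the read-out does not separate the chain with the extra double bond from the one without it. With the 2-acetylethyl chain the same in both compounds, methyl in place of ethoxy gives a number 22 percentage points higher from compound 1 to compound 3 (beyond the scatter), which ties the low number of compound 1 to its ethoxy group rather than to its chain. Nothing at hand explains either step.

On these data alone, it remains open whether a carboxylic acid at the end of the chain, or a longer chain, would keep the number at this level. As far as these compounds go, it is also open how a methoxy group or a chlorine atom would compare with methyl and ethoxy on the shared core.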